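Adding an amine to the alkyne side chain of compound 1

This account rests on a few compounds, and the source may have more. Where it says the series, first, only, none or still open, it means among the compounds named here.

Measured so far:
- compound 1 `COc1cc[nH]c1/C=C1\C(=O)Nc2ccc(F)c(C#C[C@H](C)O)c21`: 400 nM
- compound 2 `COc1cc[nH]c1/C=C1\C(=O)Nc2ccc(F)c(C#C[C@H](N)CO)c21`: 270 nM

Among the measured compounds shown here, in a functional assay on SW480 cells (Homo sapiens) for inhibition (a lower number here means a stronger inhibitor, a higher number a weaker inhibitor), compound 1 gives 400 nM, the highest of the two numbers measured here; compound 2 gives 270 nM, and the single step between them, a 1.5-fold lower number from compound 1 to compound 2 (0.17 log units; within the scatter), stays within the scatter. The unmeasured compound 3 `COc1cc[nH]c1/C=C1\C(=O)Nc2ccc(F)c(C#C[C@@H](N)[C@@H](C)O)c21` is built from compound 1 by the change (1-amino-2-hydroxypropyl in place of 1-hydroxyethyl on a triple-bonded carbon), so the 1-hydroxyethyl group becomes a 1-amino-2-hydroxypropyl group on the same triple-bonded carbon. For the measured compounds named here, the only step that bears on this is the one from compound 1 to compound 2, which also introduces an amino group on that carbon and moves the hydroxyl one atom outward; it was small. Compound 3 is therefore expected to show a step of a 1.4-fold lower number from compound 1 to compound 3 (0.15 log units; within the scatter), not beyond the scatter. The estimate for compound 3 is 280 nM, within a range from 110 nM to 700 nM.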

Compound 3, half-maximal inhibitory concentration: 210 nM
Compound 3: middle estimate off by 1.3-fold (0.12 log units), on the high side; the measured number falls inside the stated range.
By their numbers in this assay, from the lowest: compounds 3, 2 and 1 (each within the scatter of the next).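

In this assay, replacing the 1-hydroxyethyl group on the triple-bonded carbon with a 1-amino-2-hydroxypropyl group gives a 1.9-fold lower number from compound 1 to compound 3 (0.28 log units; within the scatter), so this position accepts a larger side chain than those seen earlier without a step beyond the scatter. Changing 1-amino-2-hydroxyethyl to 1-amino-2-hydroxypropyl gives a 1.3-fold lower number from compound 2 to compound 3 (0.11 log units; within the scatter), which shows that the extra carbon leaves the number within the scatter as well. Nothing available here explains how these side chains act on the cells.

From the compounds shown here alone, it remains open whether a longer chain, such as 1-amino-2-hydroxybutyl, or a carboxylic acid at this position would give a step beyond the scatter. The compounds shown also leave open what the amine does without the hydroxyl, as in a 1-aminoethyl group, and what the mirror-image arrangements of 1-amino-2-hydroxypropyl would give.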